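The source may report more compounds than this note shows. Statements on the series, on what has been measured and on what is new or still open speak of the compounds shown alone.

In an ADME assay on the whole organism (Mus musculus, strain C57BL/6) for pharmacokinetics, read by LC-MS, with a stated time of 24 h, at a dose of 2 mg/kg by the intravenous route (a higher number here means that more of the compound sits outside the plasma, a lower number that more of the compound stays in the plasma), compound 1 (`Nc1ncn(Cc2c(Cl)cccc2Cl)c2ncnc1-2`) gives 3.01 L/kg and compound 2 (`Nc1ncn(Cc2c(Cl)cncc2Cl)c2ncnc1-2`) gives 0.81 L/kg, the lower of the two numbers, with a gap beyond the usual scatter. Compound 3 (`Cc1ccccc1-c1nc2c(N)ncn(Cc3c(Cl)cncc3Cl)c-2n1`) carries 2-methylphenyl in place of hydrogen on an aromatic carbon, between two ring nitrogen atoms: 2-methylphenyl in place of hydrogen on an aromatic carbon. Among the compounds with values here, no measured pair shows such a change, so only a rise of about the size of the usual scatter is expected in this assay. The expected step is a 2.0-fold higher number from compound 2 to compound 3 (0.30 log units; within the scatter). Compound 3 is estimated at 1.6 L/kg, with an expected range from 0.7 L/kg to 3.8 L/kg.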

Compound 3, volume of distribution: 4.04 L/kg
Beside the measured number, compound 3's estimate is 2.5-fold (0.40 log units) below it, outside the stated range (above it).
By their numbers in this assay, from the lowest: compound 2; then compounds 1 and 3 (each within the scatter of the next).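

In this assay, the aromatic carbon between two ring nitrogen atoms is a position where the read-out responds: 2-methylphenyl in place of hydrogen gives a 5.0-fold higher number from compound 2 to compound 3 (0.70 log units; beyond the scatter), a step beyond the scatter. It is the only change at this position among the compounds shown, so it rests on one pair. Nothing available accounts for the rise. On these data alone, whether a plain phenyl, a methyl group or an amine on the same carbon would move the number as far stays open. So does whether 2-methylphenyl would raise the number on compound 1.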